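The source may report more compounds than this note shows. Statements on the series, on what has been measured and on what is new or still open speak of the compounds shown alone.

Measured so far:
compound 1, `CC(=O)OC/C1=C/C[C@](C)(CCC=C(C)C)/C=C/[C@@H](OC(=O)C=C(C)C)[C@](C)(OC(C)=O)/C=C/C1=O`, 4130 nM
compound 2, `CC(C)=CCC[C@]1(C)/C=C/[C@@H](OC(=O)C=C(C)C)[C@](C)(O)/C=C/C(=O)/C(CN(C)C)=C\C1`, 820 nM

In a functional assay on SMMC-7721 cells (Homo sapiens) for antiproliferative activity, read by MTT assay, with a stated time of 48 h (on this read-out lower numbers stand for stronger inhibition and higher numbers for weaker inhibition), compound 2 gives 820 nM and holds the lowest number of the two; in this assay compound 1 gives 4130 nM, a higher number by a gap that lies beyond the usual scatter. Among the measured compounds shown here, no single-point step connects the two measured compounds, as compound 1 also carries an acetyl ester on the tertiary alcohol where compound 2 has a free hydroxyl.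

Compound 3, `CSC(=S)OC/C1=C/C[C@](C)(CCC=C(C)C)/C=C/[C@@H](OC(=O)C=C(C)C)[C@](C)(O)/C=C/C1=O`, is not yet measured. It differs from compound 2 in one place: a group of 5 heavy atoms (2 carbon, 1 oxygen, 2 sulfur; no ring) in place of a group of 3 heavy atoms (2 carbon, 1 nitrogen; no ring), on a saturated chain carbon bound to a double-bonded ring carbon. Compound 1, which carries an ester at the same place, gives the weaker result of the two measured compounds, so the dimethylamino group appears to go with the stronger result, though this rests on two compounds only and the second change in compound 1 clouds the comparison.

For compound 3 a weaker result than compound 2 is expected, the estimated step being a 2.7-fold higher number from compound 2 to compound 3 (0.43 log units; beyond the scatter) in this assay, probably beyond the scatter. The expected value for compound 3 is 2200 nM, with a range of 800 nM to 6000 nM.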

Compound 3, half-maximal inhibitory concentration: 720 nM
Compound 3: middle estimate off by 3.1-fold (0.49 log units), on the high side; measured number below the stated range.
By their numbers in this assay, from the lowest: compounds 3 and 2 (each within the scatter of the next); then compound 1.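

In this assay the exchange of dimethylamino for the group of 5 heavy atoms (2 carbon, 1 oxygen, 2 sulfur; no ring), on a saturated chain carbon bound to a double-bonded ring carbon, gives a 1.1-fold lower number from compound 2 to compound 3 (0.06 log units; within the scatter) and so separates the two groups by nothing that can be read. This place in the shared core therefore accepts two groups that differ in heavy-atom count, in hydrogen-bond acceptor count and in element make-up without a gap beyond the scatter, so a nitrogen at this place is not needed for a number of this size, at least within this pair. No measurement at hand bears on why the two groups read alike.

Still open, from the compounds shown here alone, is whether a free hydroxymethyl, a morpholine or a simple primary amine at this place would stay level with these two groups. Also open, going by these compounds, is what the acetyl ester on the tertiary alcohol contributes alone, since it appears only in compound 1, which differs from the others at the chain carbon as well.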